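The source may hold more compounds than are shown below. What is called first, only, known or untested is meant among the compounds shown, and "the series" means these compounds.

Measured so far:
compound 1 `COc1cc(-c2nn(-c3cccc(NC(=O)Nc4ccc(Cl)c(Cl)c4)c3)cc2-c2ccncc2)ccc1Cl` — 40900 nM
compound 2 `COc1cc(-c2nn(-c3cccc(NC(=O)Nc4cccc(C(F)(F)F)c4)c3)cc2-c2ccncc2)ccc1Cl` — 19000 nM
compound 3 `COc1cc(-c2nn(-c3cccc(NC(=O)Nc4ccc(Cl)c(C(F)(F)F)c4)c3)cc2-c2ccncc2)ccc1Cl` — 13500 nM

In a functional assay on TK-10 cells (Homo sapiens) for inhibition, read by sulforhodamine B assay, with a stated time of 48 h (on this read-out higher numbers stand for weaker inhibition of growth and lower numbers for stronger inhibition of growth), compound 3 gives the lowest number of the three; compound 2 sits close to it, the gap being within the scatter, while compound 1 stands further off, as a 3.0-fold lower number from compound 1 to compound 3 (0.48 log units; beyond the scatter) shows. Compound 4 `COc1cc(-c2nn(-c3cccc(NC(=O)c4ccccc4)c3)cc2-c2ccncc2)ccc1Cl` differs from compound 3 by phenyl in place of (4-chloro-3-(trifluoromethyl)phenyl)amino on a carbonyl carbon. Among the compounds with values here, no measured step covers this change: a 2.2-fold lower number from compound 1 to compound 2 (0.33 log units; beyond the scatter) and a 1.4-fold lower number from compound 2 to compound 3 (0.15 log units; within the scatter), like a 3.0-fold lower number from compound 1 to compound 3 (0.48 log units; beyond the scatter), only vary substituents on the group that leaves here, and all were modest. Within the data shown here, removing that whole group together with its amino nitrogen has no precedent, so a move toward higher numbers is expected, of uncertain size. Compound 4 is therefore estimated at 45000 nM, range 15000 nM to 130000 nM, which corresponds to a 3.3-fold higher number from compound 3 to compound 4 (0.52 log units; beyond the scatter).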

Compound 4, concentration for total growth inhibition: > 100000 nM
Compound 4 was reported as a limit; the forecaster's own chance of this, stated with the estimate: 20%; middle value at least 2.2-fold (0.34 log units) away from the limit.
By their numbers in this assay, from the lowest: compounds 3 and 2 (each within the scatter of the next); then compound 1. At a limit, above all of these: compound 4.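

In this assay compound 4 stands only as a limit, > 100000 nM. Phenyl in place of the substituted phenylamino groups on this carbonyl carbon gives an at least 7.4-fold higher number from compound 3 to compound 4 (0.86 log units; beyond the scatter), an at least 5.2-fold higher number from compound 2 to compound 4 (0.72 log units; beyond the scatter) and an at least 2.4-fold higher number from compound 1 to compound 4 (0.38 log units; beyond the scatter). The first two steps already exceed the largest substituent step, a 3.0-fold lower number from compound 1 to compound 3 (0.48 log units; beyond the scatter), so this change reaches further than substituent variation did, while the step starting at compound 1 does not show this.

Whether the amino nitrogen or the ring substituents account for the loss remains open. A plain phenylamino group or a methylamino group on the same carbonyl carbon would separate the two.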